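This account rests on a few compounds, and the source may have more. Where it says the series, first, only, none or still open, it means among the compounds named here.

In a functional assay on HUVEC cells (Homo sapiens) for inhibition, with stated times of 2 h and 72 h (a higher number here means a weaker inhibitor, a lower number a stronger inhibitor), compound 1 `COc1cc2nccc(Oc3ccc4c(NC(=O)Nc5ccc(C(F)(F)F)cc5Cl)nn(C)c4c3)c2cc1OC` stands highest of three at 1150 nM, against compound 2 `COc1ccc(C(=O)Nc2nn(C)c3cc(Oc4ccnc5cc(OC)c(OC)cc45)ccc23)cc1` at 32 nM and compound 3 `COc1cc2nccc(Oc3ccc4c(NC(=O)c5cccc(C)c5)nn(C)c4c3)c2cc1OC` at 2 nM. Compound 4 `COc1cc2nccc(Oc3ccc4c(NC(=O)Nc5ccc(C)cc5)nn(C)c4c3)c2cc1OC` carries 4-methylphenyl in place of 2-chloro-4-(trifluoromethyl)phenyl on an amide-type nitrogen. Within the data shown here, no measured step makes this exact change. The closest are a 36-fold lower number from compound 1 to compound 2 (1.56 log units; beyond the scatter) and a 580-fold lower number from compound 1 to compound 3 (2.76 log units; beyond the scatter), which both replace the whole (2-chloro-4-(trifluoromethyl)phenyl)amino group, and a 16-fold lower number from compound 2 to compound 3 (1.20 log units; beyond the scatter), which swaps only the group on a carbonyl carbon. All three are large, so they bear on the change only indirectly. What is expected in this assay is a 9.6-fold lower number from compound 1 to compound 4 (0.98 log units; beyond the scatter), a large but uncertain step. Compound 4 is estimated at 120 nM, with an expected range from 12 nM to 1000 nM.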

Compound 4, half-maximal inhibitory concentration: 3 nM
Estimate against measurement, compound 4: 40-fold (1.60 log units) above, and the stated range ends above it.
By their numbers in this assay, from the lowest: compounds 3 and 4 (each within the scatter of the next); then compound 2; then compound 1.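

In this assay, changing only the group on the amide-type nitrogen gives a 380-fold lower number from compound 1 to compound 4 (2.58 log units; beyond the scatter), so the high number of compound 1 does not come from the (aryl)amino link to the carbonyl as such. That link can match a directly attached aryl group, as a 1.5-fold higher number from compound 3 to compound 4 (0.18 log units; within the scatter) lies within the scatter, while an 11-fold lower number from compound 2 to compound 4 (1.03 log units; beyond the scatter) is a large step. No evidence here accounts for the size of these steps.

The compounds shown do not separate the 2-chloro from the 4-(trifluoromethyl) part of the group that leaves. A 2-chlorophenyl or a 4-(trifluoromethyl)phenyl on the same nitrogen would address that.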